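A few compounds are considered here, and "the series" means these few. Any claim that something is new, unique, unknown or untested is made for them only; others in the source may bear on it.

Series notes. In a functional assay on L02 cells (Homo sapiens) for inhibition, read by MTT assay, with a stated time of 48 h (on this read-out higher numbers stand for weaker inhibition and lower numbers for stronger inhibition), compound 1 `COc1ccc2c(=O)c(/C=C/C(=O)NCc3ccc(F)cc3)coc2c1` gives > 200000 nM, which is a limit of the assay and not a number. Compound 2 `COc1ccc2c(=O)c(/C=C/C(=O)NCc3ccccc3F)coc2c1` likewise gives only a limit, > 200000 nM. Compound 3 `COc1ccc2c(=O)c(/C=C/C(=O)Nc3ccccc3OC)coc2c1` also gives only a limit, > 200000 nM. Where compound 3 stands among the values shown is thus fixed only by this limit; it is not separated from the other two. The steps a step that the two limits leave unreadable from compound 1 to compound 2, a step that the two limits leave unreadable from compound 1 to compound 3 and a step that the two limits leave unreadable from compound 2 to compound 3 cannot be read in size, since (the limit of > 200000 nM in this assay, at which 3 of the 3 values shown sit). Compound 4 `COc1ccc2c(=O)c(/C=C/C(=O)Nc3ccccc3C)coc2c1` differs from compound 3 by methyl in place of methoxy on an aromatic carbon; the place is on an aromatic carbon of a six-membered aromatic ring of carbon only, ortho to a large group. Going by the values given here, none of the measured steps yields a readable size, so no direction can be drawn from them; the three limits show only weak inhibition across the series so far. Compound 4 is therefore expected to give 200000 nM, with a range from 60000 nM to 400000 nM, most likely again reported as a limit. The step of a number no higher from compound 3 to compound 4 (the limit leaves the size open) is expected to stay within the scatter.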

Compound 4, half-maximal inhibitory concentration: > 200000 nM
Compound 4: only a limit was reported (the forecaster's own chance of this, stated with the estimate: 80%); the middle value lies on the limit itself.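

No new step can be read between compound 4 and compound 1, compound 2 or compound 3, because each gives only a limit and not a number: the limit of > 200000 nM in this assay, at which 4 of the 4 values shown sit.

The compounds shown leave open how strongly any of the four inhibits in this assay, and whether methyl and methoxy differ there at all.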